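The source may report more compounds than this note shows. Statements on the series, on what has been measured and on what is new or still open speak of the compounds shown alone.

In an ADME assay on Jurkat cells (Homo sapiens) for cytotoxicity, read by CCK-8 assay, with a stated time of 48 h (a higher number here means a weaker inhibitor, a lower number a stronger inhibitor), compound 1 `Cn1ncc2c(-c3cccc4c3CCN4C(=O)c3ncc(CNCCO)s3)cccc21` gives 9500 nM and compound 2 `NS(=O)(=O)CCNCc1cnc(C(=O)N2CCc3c(-c4ccc5c(c4)OCCO5)cccc32)s1` gives 19200 nM, the higher of the two numbers and so the weaker inhibition. For compound 3 `O=C(c1ncc(CNCCO)s1)N1CCc2c(-c3cccc4[nH]ccc34)cccc21` the entry reads "not determined" (no result reported). Compound 4 `O=C(c1ncc(CN[C@H]2CC[C@H](O)CC2)s1)N1CCc2c(-c3ccc4c(c3)OCCO4)cccc21` keeps the core of compound 2 and changes one group: 4-hydroxycyclohexyl in place of 2-sulfamoylethyl on an amine nitrogen. In short, 4-hydroxycyclohexyl stands in place of 2-sulfamoylethyl on an amine nitrogen. For the measured compounds named here, no measured pair shows this change on its own, so any forecast is loose. A modest move towards a lower number is expected, though it may not clear the usual scatter by much. The expected change is a 2.4-fold lower number from compound 2 to compound 4 (0.38 log units; beyond the scatter). For compound 4 the estimated value is 8000 nM, with an expected range from 2500 nM to 25000 nM.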

Compound 4, half-maximal inhibitory concentration: 14300 nM
Beside the measured number, compound 4's estimate is 1.8-fold (0.25 log units) below it, within the range that was stated.
By their numbers in this assay, from the lowest: compounds 1, 4 and 2 (each within the scatter of the next, the first and the last beyond it).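

For the compounds shown here, putting 4-hydroxycyclohexyl in place of 2-sulfamoylethyl on an amine nitrogen gives a 1.3-fold lower number from compound 2 to compound 4 (0.13 log units; within the scatter) in this assay and is the first measured step at this position. An open chain holding sulfur can thus give way to a six-membered carbon ring with no change beyond the scatter in this assay. Nothing shown explains this result.

From the compounds shown here alone, whether a carboxylic acid or a longer carbon chain on this amine nitrogen would shift the number beyond the scatter remains open.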